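The source may report more compounds than this note shows. Statements on the series, on what has been measured and on what is new or still open speak of the compounds shown alone.

Two compounds have been measured in a functional assay on MDA-MB-468 cells (Homo sapiens) for inhibition, read by sulforhodamine B assay, with a stated time of 48 h; a higher number here means a weaker inhibitor of growth, a lower number a stronger inhibitor of growth:

compound 1, `COc1cc(-c2nn(-c3cccc(NC(=O)Nc4ccc(Cl)c(Cl)c4)c3)cc2-c2ccncc2)ccc1Cl`: compound 1 gives 567 nM
compound 2, `COc1cc(-c2nn(-c3cccc(NC(=O)Nc4cccc(C(F)(F)F)c4)c3)cc2-c2ccncc2)ccc1Cl`: compound 2 gives 598 nM

Among the measured compounds shown here, compound 2 has the higher of the two numbers in this assay, but the only step measured, a 1.1-fold higher number from compound 1 to compound 2 (0.02 log units; within the scatter), stays within the scatter, so compound 2 and compound 1 cannot be told apart on these data.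

Compound 3, `COc1cc(-c2nn(-c3cccc(NC(=O)c4ccc(Cl)c(C(F)(F)F)c4)c3)cc2-c2ccncc2)ccc1Cl`, is the next compound and has not yet been measured. It differs from compound 2 in one place: 4-chloro-3-(trifluoromethyl)phenyl in place of (3-(trifluoromethyl)phenyl)amino on a carbonyl carbon. The carbonyl keeps one amide-type nitrogen but the second nitrogen of compound 2 is gone, and a chlorine appears on the ring that now sits directly on the carbonyl.

For the measured compounds named here, the one measured step, a 1.1-fold higher number from compound 1 to compound 2 (0.02 log units; within the scatter), swapped only the substituents on that outer ring and left the number unchanged within the scatter. Going by the values given here, no measured step removes a nitrogen link from the carbonyl, so there is nothing to show the direction or size of that part of the change. The expectation is therefore a step of a 1.2-fold higher number from compound 2 to compound 3 (0.07 log units; within the scatter) in this assay, with wide uncertainty. Compound 3 is expected to give about 700 nM, in a range from 200 nM to 2500 nM.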

Compound 3, concentration for 50% growth inhibition: 3690 nM
Estimate against measurement, compound 3: 5.3-fold (0.72 log units) below; measured number above the stated range.
By their numbers in this assay, from the lowest: compounds 1 and 2 (each within the scatter of the next); then compound 3.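

In this assay the place on the carbonyl carbon proves sensitive to change, whereas the earlier swap on the outer ring left the number within the scatter: the data give a 6.2-fold higher number from compound 2 to compound 3 (0.79 log units; beyond the scatter) and a 6.5-fold higher number from compound 1 to compound 3 (0.81 log units; beyond the scatter) and both steps lie beyond the scatter. Compound 3 is therefore a weaker inhibitor of growth than either compound 1 or compound 2, and this single change both removes the nitrogen link to the outer ring, with the hydrogen-bond donor counted on the group that leaves, and brings in 4-chloro-3-(trifluoromethyl)phenyl with its added chlorine. Nothing available here offers an explanation for this loss of growth inhibition.

The compounds shown leave open how much of the step goes with losing the nitrogen and how much goes with gaining the chlorine, since the two changes arrive together in compound 3. They also leave open whether an oxygen atom or a methylene group in place of that nitrogen, linking the carbonyl to the outer ring, would give a number closer to compound 1 and compound 2 or closer to compound 3.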